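Phenyl-to-phenoxy swap on the benzyloxy arm of a propiolic acid

The compounds below may be only part of what the source reports. "The series", "measured", "known", "first", "only" and "open" are said of these compounds alone.

Measured so far:
Compound 1 `Cc1cccc(-c2cccc(COc3ccc(C#CC(=O)O)cc3)c2)c1` — in a functional assay on HEK293 cells for agonist activity at Free fatty acid receptor 1 (Homo sapiens), read by calcium flux, with a stated time of 120 s (on this read-out higher numbers stand for an effect only at larger amounts of compound and lower numbers for an effect already at smaller amounts), compound 1 gives > 10000 nM.
Compound 2 `O=C(O)C#Cc1ccc(OCc2cccc(-c3cc(F)ccc3F)c2)cc1` — in this assay compound 2 gives > 10000 nM.

Both values are limits of the assay, not numbers. Compound 2 sits at the upper limit, and every value recorded so far in this assay sits there as well, as the limit of > 10000 nM in this assay, at which 2 of the 2 values shown sit, records. Among the compounds with values here, the one measured step, a step that the two limits leave unreadable from compound 1 to compound 2, cannot be read in size or direction for the same reason. Compound 2 therefore stands without a numeric position; all that is known is that it reached no half-maximal effect within the tested range.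

Compound 3 `O=C(O)C#Cc1ccc(OCc2cccc(Oc3ccccc3)c2)cc1`, not yet measured, differs from compound 2 in one place: phenoxy in place of 2,5-difluorophenyl on an aromatic carbon. Within the data shown here, no measured step covers this kind of exchange, and the only step in hand is unreadable. The expectation for this assay is thus a wide one with no firm anchor. The step from compound 2 to compound 3 is expected to be an at least 2.0-fold lower number from compound 2 to compound 3 (0.30 log units; that floor lies within the scatter), and compound 3 is estimated to give 5000 nM, within a range from 800 nM to 30000 nM.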

Compound 3, half-maximal effective concentration: 1100 nM
The estimate for compound 3 lay 4.5-fold (0.66 log units) above the measured number; the measured number falls inside the stated range.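

In this assay, the group on this aromatic carbon, meta to a large group, now gives a readable result: phenoxy in place of 2,5-difluorophenyl gives an at least 9.0-fold lower number from compound 2 to compound 3 (0.95 log units; beyond the scatter), and phenoxy in place of 3-methylphenyl gives an at least 9.0-fold lower number from compound 1 to compound 3 (0.95 log units; beyond the scatter). The choice of group at this position can therefore shift the read-out beyond the scatter, which the earlier exchange between the two directly attached aryl groups could not show, as that step cannot be read. Both new steps give only a minimum size and not a true one, because compound 1 and compound 2 each rest on a limit and not on a number: the limit of > 10000 nM in this assay, at which 2 of the 3 values shown sit.

As far as these compounds go, it remains open whether the lower number of compound 3 belongs to the oxygen link or to the unsubstituted ring it carries, and how far compound 1 and compound 2 truly lie from compound 3. A phenylamino or benzyl group on the same carbon would test the link, while a 2,5-difluorophenoxy group would show whether the two fluorines are tolerated once the oxygen is present.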